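Swapping one aromatic ring for another on the fused ring

The compounds below may be only part of what the source reports. "The series", "measured", "known", "first", "only" and "open" are said of these compounds alone.

Among the measured compounds shown here, the three compounds measured so far share a core and differ at two places. In an assay on COS-7 cells for inhibition of tyrosine-protein kinase receptor UFO (Homo sapiens), read by ELISA, with a stated time of 1 h (a higher number here means a weaker inhibitor, a lower number a stronger inhibitor), compound 1, `Cc1nn(C)c(C)c1-c1ccc(-c2nnc(N(C)Cc3ccc4nccn4c3)o2)c(F)c1`, gives 3160 nM. Compound 2, `Cc1cc(-c2c(C)nn(C)c2C)ccc1-c1nnc(N(C)Cc2ccc3nccn3c2)o1`, gives 398 nM in this assay, and the change a 7.9-fold lower number from compound 1 to compound 2 (0.90 log units; beyond the scatter) is the larger of the two steps seen. Compound 3, `Cc1cc(-c2c(C)nn(C)c2C)ccc1-c1nnc(N(C)Cc2ccc3ncc(-c4ccccc4)n3c2)o1`, gives 200 nM in this assay, the lowest of the three numbers; its gap to compound 2 is within the scatter, so the two cannot be put in order, while its gap to compound 1 lies beyond the scatter.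

Compound 4, `Cc1cc(-c2c(C)nn(C)c2C)ccc1-c1nnc(N(C)Cc2ccc3ncc(-c4cnn(C)c4)n3c2)o1`, differs from compound 3 by 1-methyl-1H-pyrazol-4-yl in place of phenyl on an aromatic carbon. The step that bears on this place is a 2.0-fold lower number from compound 2 to compound 3 (0.30 log units; within the scatter), which lies within the scatter. Putting an aromatic ring on this carbon has therefore changed the number little, and replacing that ring by another aromatic ring of the same size is expected to change it little as well. The expected step is no change at the digits printed from compound 3 to compound 4 (within the scatter), with no movement beyond the scatter in either direction. In this assay compound 4 is estimated at 200 nM, within a range from 80 nM to 500 nM.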

Compound 4, half-maximal inhibitory concentration: 63.1 nM
Beside the measured number, compound 4's estimate is 3.2-fold (0.50 log units) above it, and the stated range ends above it.
By their numbers in this assay, from the lowest: compound 4; then compounds 3 and 2 (each within the scatter of the next); then compound 1.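

Putting 1-methyl-1H-pyrazol-4-yl in place of phenyl on this carbon gives a 3.2-fold lower number from compound 3 to compound 4 (0.50 log units; beyond the scatter) in this assay, so the kind of aromatic ring placed here can matter, not just whether a ring is present. Set against hydrogen on the same carbon, the new group gives a 6.3-fold lower number from compound 2 to compound 4 (0.80 log units; beyond the scatter), whereas the step from hydrogen to phenyl stayed within the scatter; this is the first clear gain from substitution at this position among the compounds shown. Phenyl and 1-methyl-1H-pyrazol-4-yl have the same number of heavy atoms but differ in ring size, nitrogen content and hydrogen-bond acceptors, and no supporting data are available to show which of these differences matters.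

From the compounds shown here alone, it remains open whether the methyl on the pyrazole takes part in the change, which the unsubstituted 1H-pyrazol-4-yl group would test, or whether another nitrogen-containing aromatic ring, such as pyridin-3-yl, would give a similar number. Also unresolved is whether this carbon needs an aromatic ring at all, a question that a saturated ring such as morpholine or a simple amine would address.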